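Oxazole Ketone Inhibitors: Swapping a Formyl End Group

This account rests on a few compounds, and the source may have more. Where it says the series, first, only, none or still open, it means among the compounds named here.

Compounds measured so far:
compound 1, `O=C(CCCCCCc1ccccc1)c1ncc(-c2ccc(CO)cn2)o1`, 3.2 nM;
compound 2, `CSC(=O)CCCCc1cnc(C(=O)CCCCCCc2ccccc2)o1`, 1.8 nM;
compound 3, `O=CCCCCc1cnc(C(=O)CCCCCCc2ccccc2)o1`, 14.6 nM.

In an assay for inhibition of Fatty-acid amide hydrolase 1 (Rattus norvegicus), using a Dixon plot (a lower number here means a stronger inhibitor, a higher number a weaker inhibitor), compound 3 gives the highest number of the three. Its nearest neighbour is compound 1, reached by a 4.6-fold higher number from compound 1 to compound 3 (0.66 log units; beyond the scatter); the largest gap separates it from compound 2, shown by an 8.1-fold higher number from compound 2 to compound 3 (0.91 log units; beyond the scatter). Both steps lie beyond the scatter, so compound 3 is the weakest inhibitor among the measured set.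

Compound 4, `N#CCCCCCc1cnc(C(=O)CCCCCCc2ccccc2)o1`, differs from compound 3 in one place: cyanomethyl in place of formyl on a saturated chain carbon, four bonds along the chain from an aromatic carbon. The step that speaks to this change is the one at the same chain end, from compound 2 to compound 3, where a hydrogen replaced methylsulfanyl on the carbonyl carbon and the number rose beyond the scatter. Among the measured compounds shown here, compound 4 instead exchanges the whole formyl for cyanomethyl, a change for which no measured pair gives a direct comparison. He therefore expects no step beyond the scatter in this assay, a 1.4-fold higher number from compound 3 to compound 4 (0.14 log units; within the scatter), and estimates compound 4 at 20 nM, within 5 nM to 80 nM.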

Compound 4, inhibition constant: 4.8 nM
Estimate against measurement, compound 4: 4.2-fold (0.62 log units) above; measured number outside the range, below it.
By their numbers in this assay, from the lowest: compounds 2, 1 and 4 (each within the scatter of the next, the first and the last beyond it); then compound 3.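

In this assay, cyanomethyl in place of formyl on this saturated chain carbon gives a 3.0-fold lower number from compound 3 to compound 4 (0.48 log units; beyond the scatter), which shows that the chain end need not carry a formyl to reach a lower number. The nitrile-ended chain still does not match the (methylsulfanyl)carbonyl end, with a 2.7-fold higher number from compound 2 to compound 4 (0.43 log units; beyond the scatter), while the exchange of 5-cyanopentyl for 5-(hydroxymethyl)pyridin-2-yl on the aromatic carbon gives a 1.5-fold higher number from compound 1 to compound 4 (0.18 log units; within the scatter), so these two very different substituents stay within the scatter of each other. No measurement shown here accounts for these differences.

The change from formyl to cyanomethyl alters both the end group and the length of the chain, and these compounds do not separate the two. Going by these compounds, it remains open how a carboxylic acid, an amine or a longer nitrile-ended chain would read at this place.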